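The source may hold more compounds than are shown below. What is called first, only, known or untested is meant among the compounds shown, and "the series" means these compounds.

Measured so far in a functional assay on CHO cells for agonist activity at Free fatty acid receptor 1 (Homo sapiens), read by FLIPR and calcium flux, in the presence of a further agent that is not named here; on this read-out lower numbers stand for an effect already at smaller amounts and higher numbers for an effect only at larger amounts of compound:
- compound 1, `CCc1ccc(-c2noc(COc3ccc(CCC(=O)O)cc3)n2)cc1`, 210 nM
- compound 2, `Cc1ccc(-c2noc(COc3ccc(CCC(=O)O)cc3)n2)cc1`, 300 nM

Compound 2 has the higher of the two numbers in this assay, but the gap to compound 1 is small: the step of a 1.4-fold higher number from compound 1 to compound 2 (0.15 log units; within the scatter) lies within the scatter, so the two compounds cannot be ordered on these data.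

Compound 3, `O=C(O)CCc1ccc(OCc2nc(-c3cccc(Br)c3)no2)cc1`, has not yet been measured. It differs from compound 2 by 3-bromophenyl in place of 4-methylphenyl on an aromatic carbon.

Within the data shown here, only one measured step exists, and it concerns the same aryl group: it removes the methyl and leaves the ring otherwise unchanged, with no effect beyond the scatter. Among the measured compounds shown here, the change to compound 3 is larger in kind, since it both removes the methyl and brings in bromine at a different ring position, and no measured pair shows what a bromine on this ring does. For the measured compounds named here, with the one available step flat, the working expectation for compound 3 is a number close to that of compound 2, estimated as a step of no change at the digits printed from compound 2 to compound 3 (within the scatter) in this assay, with a wide range to cover the unknown effect of the bromine. Compound 3 is therefore expected to give about 300 nM, in the range 100 nM to 900 nM.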

Compound 3, half-maximal effective concentration: 1260 nM
Compound 3: middle estimate off by 4.2-fold (0.62 log units), on the low side, outside the stated range (above it).
By their numbers in this assay, from the lowest: compounds 1 and 2 (each within the scatter of the next); then compound 3.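

In this assay, the aryl group on the aromatic carbon of the five-membered ring, two ring bonds from the ring oxygen, now gives a change beyond the scatter: 3-bromophenyl in place of 4-methylphenyl gives a 4.2-fold higher number from compound 2 to compound 3 (0.62 log units; beyond the scatter), and 3-bromophenyl in place of 4-ethylphenyl gives a 6.0-fold higher number from compound 1 to compound 3 (0.78 log units; beyond the scatter). The earlier pair differed only in the length of the alkyl group on the 4-substituted phenyl and could not be ordered, so this position responds to the aryl group more than that pair alone showed, and the direction of both steps is towards a higher number. Nothing at hand accounts for the rise, and no measurement of any property of these groups bears on it.

Compound 3 changes the substituent and its place on the phenyl ring at once, so the higher number cannot yet be assigned to the bromine or to the new ring position; a 4-bromophenyl or a 3-methylphenyl group would separate the two. Going by these compounds, how an unsubstituted phenyl, a 3-chlorophenyl or a 4-methoxyphenyl group would read at this position also stays open.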